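Carbamate chain length in the metabolic stability series

The source may hold more compounds than are shown below. What is called first, only, known or untested is meant among the compounds shown, and "the series" means these compounds.

Compound 1 `CCCCCCCCNC(=O)Oc1ccc(Cl)cc1C(=O)Nc1cccc(Cl)c1` and compound 2 `CCCCCCCCCCNC(=O)Oc1ccc(Cl)cc1C(=O)Nc1cccc(Cl)c1` share a core and differ by ethyl in place of hydrogen on a saturated chain carbon, eight bonds along the chain from an amide-type nitrogen. In an ADME assay for metabolic stability, read by HPLC, at pH 7 (a lower number here means that the compound disappears faster, a higher number that the compound lasts longer), compound 1 gives 64 h, and compound 2 gives 64 h; the step is no change at the digits printed from compound 1 to compound 2 (within the scatter). Compound 3 `CCCNC(=O)Oc1ccc(Cl)cc1C(=O)Nc1ccc(Cl)cc1` has a different core, and the difference between the two cores is not broken down here; in this assay compound 3 gives 64 h, level with compounds 1 and 2. Compound 4 `CCCCCNC(=O)Oc1ccc(Cl)cc1C(=O)Nc1ccc(Cl)cc1` differs from compound 3 by ethyl in place of hydrogen on a saturated chain carbon, three bonds along the chain from an amide-type nitrogen. This is the same kind of change as that from compound 1 to compound 2, though not the same: there the ethyl enters eight bonds along the chain from an amide-type nitrogen, here three bonds along. The step expected is no change at the digits printed from compound 3 to compound 4 (within the scatter), because no change at the digits printed from compound 1 to compound 2 (within the scatter) shows the earlier chain extension left the half-life unchanged. Compound 4 is therefore estimated at 64 h, between 32 h and 128 h.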

Compound 4, half-life: 64 h
Estimate against measurement, compound 4: no gap at the digits printed; the measured number falls inside the stated range.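

In this assay, ethyl in place of hydrogen gives no change at the digits printed from compound 3 to compound 4 (within the scatter). Set beside the earlier step on the core of compound 1, the change carries over between these two cores: the same change on two cores in this assay, no change at the digits printed (within the scatter) from compound 1 to compound 2 and no change at the digits printed (within the scatter) from compound 3 to compound 4, 1.0-fold (0.00 log units) apart, within the scatter of two such steps. This rests on two cores only, with the ethyl entering eight bonds along the chain in one case and three bonds along in the other, and since both steps are flat, it shows that an absence of change carries over, not that a change of real size would.

Still open, going by these compounds, is whether a longer chain on the core of compound 3 stays level in half-life. Also open, on these data alone, is whether an amine or a carboxylic acid at the chain end does.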